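Methyl for bromo on the phenoxy ring of a weak benzamide

The source may hold more compounds than are shown below. What is called first, only, known or untested is meant among the compounds shown, and "the series" means these compounds.

Measured so far:
compound 1, `Nc1ccccc1NC(=O)c1ccc(COc2ccc(Br)cc2)cc1`: 24400 nM
compound 2, `Nc1ccccc1NC(=O)/C=C/c1ccc(CN2CCc3ccccc32)cc1`: 13400 nM

Both numbers come from a functional assay on A549 cells (Homo sapiens) for antiproliferative activity, read by CCK-8 assay, with a stated time of 72 h; on this read-out lower numbers stand for stronger inhibition and higher numbers for weaker inhibition. Compound 1 stands at the top of the two numbers, but compound 2 sits within the scatter of it, so the two cannot be told apart on this read-out; both are weak. For the measured compounds named here, no pair differing in one place has been measured, so no step size is known.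

Compound 3, `Cc1ccc(OCc2ccc(C(=O)Nc3ccccc3N)cc2)cc1`, is the next compound to be measured in this assay. It differs from compound 1 by methyl in place of bromo on an aromatic carbon. A one-atom swap of this kind, on a ring far from the shared core, gives no ground in the present data for a step beyond the scatter in either direction. The expected step of a 1.2-fold higher number from compound 1 to compound 3 (0.09 log units; within the scatter) is therefore set close to none. Compound 3 is estimated at 30000 nM, with a range from 10000 nM to 80000 nM.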

Compound 3, half-maximal inhibitory concentration: 5430 nM
Compound 3: the middle estimate sits 5.5-fold (0.74 log units) above what was measured; measured number outside the range, below it.
By their numbers in this assay, from the lowest: compound 3; then compounds 2 and 1 (each within the scatter of the next).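

In this assay methyl in place of bromo gives a 4.5-fold lower number from compound 1 to compound 3 (0.65 log units; beyond the scatter) and so marks this place on the phenoxy ring, para to a large group, as one where the substituent registers on the read-out. The swap exchanges one heavy atom for one heavy atom, with no ring, hydrogen-bond donor, hydrogen-bond acceptor or net charge entering or leaving, yet the step still lies beyond the scatter. No measured property of either compound bears on this step, and its origin stays unexplained.

With only bromo and methyl shown at this place, the unsubstituted phenoxy ring and groups such as methoxy, a dimethylamino group or a longer alkyl chain remain open. Also open, as far as these compounds go, is whether methyl gives a similar step at other places on that ring.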